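The source may hold more compounds than are shown below. What is called first, only, known or untested is meant among the compounds shown, and "the series" means these compounds.

Measured so far:
- Compound 1 `C#CCOc1ccc2c(=O)c(-c3cc(OC)c(OC)cc3OC)coc2c1`: 6450 nM
- Compound 2 `COc1cc(OC)c(-c2coc3cc(OCC(=O)c4cccc(C(F)(F)F)c4)ccc3c2=O)cc1OC`: > 10000 nM
- Compound 3 `COc1cc(OC)c(-c2coc3cc(OCc4ccccc4Cl)ccc3c2=O)cc1OC`: > 10000 nM

In a functional assay on U-251 cells (Homo sapiens) for antiproliferative activity, read by MTT assay, with a stated time of 24 h (on this read-out lower numbers stand for stronger inhibition and higher numbers for weaker inhibition), compound 3 gives no number, only a limit; it stands at the limit of > 10000 nM in this assay, at which 2 of the 3 values shown sit. Compound 4 `COc1cc(OC)c(-c2coc3cc(OCc4ccc(C(F)(F)F)cc4)ccc3c2=O)cc1OC` carries 4-(trifluoromethyl)phenyl in place of 2-chlorophenyl on a saturated chain carbon bound to an oxygen on an aromatic ring.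

Among the measured compounds shown here, three measured steps bear on this change. The first is an at least 1.5-fold higher number from compound 1 to compound 3 (0.19 log units; that floor lies within the scatter), the second at least 1.5-fold higher number from compound 1 to compound 2 (0.19 log units; that floor lies within the scatter), and the third step that the two limits leave unreadable from compound 2 to compound 3. None gives a firm size for such a swap. No step beyond the scatter is therefore expected, resting on compound 3 and its limit of > 10000 nM. For compound 4 the estimated value is 12000 nM, with an expected range of 6000 nM to 30000 nM. The expected change is a step that the limit leaves unreadable from compound 3 to compound 4.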

Compound 4, half-maximal inhibitory concentration: 3750 nM
For compound 4 the middle estimate is 3.2-fold (0.51 log units) above the measured one; the measured number lies below the stated range.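

Among the compounds shown here, putting 4-(trifluoromethyl)phenyl in place of 2-chlorophenyl on this saturated chain carbon gives an at least 2.6-fold lower number from compound 3 to compound 4 (0.42 log units; beyond the scatter), one of the first steps at this position in this assay that clearly lies beyond the scatter. The same group in place of (3-(trifluoromethyl)phenyl)carbonyl gives an at least 2.6-fold lower number from compound 2 to compound 4 (0.42 log units; beyond the scatter), so what sits here does change the read-out. In place of ethynyl it gives a 1.7-fold lower number from compound 1 to compound 4 (0.24 log units; within the scatter), which does not separate those two groups.

The compounds shown leave open which part of the swap matters, the chlorine leaving or the trifluoromethyl entering. From the compounds shown here alone, how an amine or a carboxylic acid on this ring would read also remains open.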